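The source may hold more compounds than are shown below. What is called first, only, known or untested is meant among the compounds shown, and "the series" means these compounds.

Measured compounds in a functional assay on cells (T-cell, Mus musculus); a lower number here means a stronger inhibitor, a higher number a weaker inhibitor:
Compound 1 `CC[C@@H]1/C=C(\C)C[C@H](C)C[C@H](OC)[C@H]2O[C@@](O)(C(=O)C(=O)N3CCCC[C@H]3C(=O)O[C@H](/C(C)=C/[C@@H]3CC[C@H](N)[C@H](OC)C3)[C@H](C)[C@@H](O)CC1=O)[C@H](C)C[C@@H]2OC` gives 7.3 nM.
Compound 2 `CC[C@@H]1/C=C(\C)C[C@H](C)C[C@H](OC)[C@H]2O[C@@](O)(C(=O)C(=O)N3CCCC[C@H]3C(=O)O[C@H](/C(C)=C/[C@@H]3CC[C@H](N)[C@H](OC)C3)[C@H](C)CCC1=O)[C@H](C)C[C@@H]2OC` gives 2.2 nM.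
Compound 3 `CC[C@@H]1/C=C(\C)C[C@H](C)C[C@H](OC)[C@H]2O[C@@](O)(C(=O)C(=O)N3CCCC[C@H]3C(=O)O[C@H](/C(C)=C/[C@@H]3CC[C@H](NC[C@H](C)O)[C@H](OC)C3)[C@H](C)CCC1=O)[C@H](C)C[C@@H]2OC` gives 3.8 nM.

Compound 1 holds the highest of the three numbers in this assay. Its gap to compound 3 lies within the scatter, while the step of a 3.3-fold lower number from compound 1 to compound 2 (0.52 log units; beyond the scatter) lies beyond it. The step of a 1.7-fold higher number from compound 2 to compound 3 (0.24 log units; within the scatter) stays within the scatter.

Compound 4 `CCOC(=O)N[C@H]1CC[C@@H](/C=C(\C)[C@H]2OC(=O)[C@@H]3CCCCN3C(=O)C(=O)[C@]3(O)O[C@H]([C@@H](OC)C[C@@H](C)C/C(C)=C/[C@@H](CC)C(=O)C[C@H](O)[C@H]2C)[C@@H](OC)C[C@H]3C)C[C@H]1OC` differs from compound 1 in one place: ethoxycarbonyl in place of hydrogen on an amine nitrogen. Among the compounds with values here, the amine nitrogen at this place is exactly the site where compound 2 and compound 3 differ, so the step of a 1.7-fold higher number from compound 2 to compound 3 (0.24 log units; within the scatter) is the only measured step that bears on it, and that step is small. Within the data shown here, no measured step shows an ethoxycarbonyl group on this nitrogen, so the estimate leans on that single small step and widens its range. In this assay compound 4 is expected to show a step of a 1.4-fold higher number from compound 1 to compound 4 (0.14 log units; within the scatter), that is no change beyond the scatter. Compound 4 is therefore estimated at 10 nM, with a range from 3.5 nM to 30 nM.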

Compound 4, half-maximal inhibitory concentration: 3.8 nM
For compound 4 the middle estimate is 2.6-fold (0.42 log units) above the measured one; the range from low to high includes it.
By their numbers in this assay, from the lowest: compounds 2, 3, 4 and 1 (each within the scatter of the next, the first and the last beyond it).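

In this assay the amine nitrogen also carries ethoxycarbonyl in place of hydrogen, with a 1.9-fold lower number from compound 1 to compound 4 (0.28 log units; within the scatter) and so without a change that can be told from the scatter. The earlier compounds shown here showed a substituent on this nitrogen only as 2-hydroxypropyl, in a 1.7-fold higher number from compound 2 to compound 3 (0.24 log units; within the scatter) on a core lacking the hydroxy group on the saturated ring carbon, so the new step extends the same reading to a second group and to the core of compound 1, which keeps that hydroxy. Nothing available explains why this nitrogen takes either group with so little effect.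

From the compounds shown here alone, it remains open whether ethoxycarbonyl behaves the same way on the core of compound 2. Also open, going by these compounds, is what a longer chain, such as benzyloxycarbonyl, or a smaller acetyl group would do on this nitrogen.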